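Thiocarbamoyl on the ring nitrogen: two aryl variants compared

A few compounds are considered here, and "the series" means these few. Any claim that something is new, unique, unknown or untested is made for them only; others in the source may bear on it.

Compound 1 `CNC(=O)c1cc(Oc2ccc(C3=NNC(c4cccc(Cl)c4Cl)C3)cc2)ccn1` is the parent of this pair. In a functional assay on A549 cells (Homo sapiens) for cytotoxicity, read by MTT assay, with a stated time of 72 h (on this read-out lower numbers stand for stronger inhibition and higher numbers for weaker inhibition), compound 1 gives 12100 nM. Compound 3 `CNC(=O)c1cc(Oc2ccc(C3=NN(C(N)=S)C(c4cccc(Cl)c4Cl)C3)cc2)ccn1` carries the change (a group of 3 heavy atoms (1 carbon, 1 nitrogen, 1 sulfur; no ring) in place of a hydrogen atom, on an amine nitrogen in a ring). For compound 3 this assay reports only a limit, > 50000 nM. The resulting step is an at least 4.1-fold higher number from compound 1 to compound 3 (0.61 log units; beyond the scatter); it rests on (the limit of > 50000 nM in this assay, at which 1 of the 3 values shown sits), so its true size is open upward.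

Compound 2 `CNC(=O)c1cc(Oc2ccc(C3CC(c4ccc([N+](=O)[O-])cc4)=NN3)cc2)ccn1` carries a different aryl group on the shared core; the difference between the two cores is not broken down here. In this assay compound 2 has "not determined" (no result reported), so no number stands for it.

Compound 4 `CNC(=O)c1cc(Oc2ccc(C3CC(c4ccc([N+](=O)[O-])cc4)=NN3C(N)=S)cc2)ccn1` stands to compound 2 as compound 3 stands to compound 1: the change is a group of 3 heavy atoms (1 carbon, 1 nitrogen, 1 sulfur; no ring) in place of a hydrogen atom, on an amine nitrogen in a ring. It is the same kind of change, not the same change, since the surroundings differ. In compound 3 the new group sits next to the ring atom that bears a 2,3-dichlorophenyl group and two ring bonds from the ring atom that bears a large group, whereas in compound 4 it sits next to the ring atom that bears a large group and two ring bonds from the ring atom that bears a 4-nitrophenyl group.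

Among the measured compounds shown here, with no number for compound 2, the expectation for compound 4 can rest only on the one measured step, an at least 4.1-fold higher number from compound 1 to compound 3 (0.61 log units; beyond the scatter), which points to a weak result and quite possibly a limit. Compound 4 is therefore expected to give about 50000 nM in this assay, estimated to lie between 15000 nM and 150000 nM.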

Compound 4, half-maximal inhibitory concentration: > 50000 nM
Compound 4: only a limit was reported (the forecaster's own chance of this, stated with the estimate: 60%); the middle value sits exactly at the limit.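

In this assay compound 4 gives only a limit, > 50000 nM. Among the compounds shown here, compound 2 has no number, so no step from compound 2 to compound 4 can be read. The compounds shown leave open how far compound 3 and compound 4 lie past this limit, and whether the added group has the same size of effect with the 4-nitrophenyl group as with the 2,3-dichlorophenyl group.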